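Adding chloro to compound 1: expectation for compound 3

The source may hold more compounds than are shown below. What is called first, only, known or untested is meant among the compounds shown, and "the series" means these compounds.

Measured in a functional assay on Ishikawa cells (Homo sapiens) for antiproliferative activity, read by MTT assay, with a stated time of 48 h; a higher number here means a weaker inhibitor, a lower number a stronger inhibitor
compound 1 `O=C1NC2(C3=C(C(=O)C4C=CC=CC4C3=O)c3ccccc32)c2ccccc21` gives 1900 nM
compound 2 `O=C1NC2(C3=C(C(=O)C4C=CC=CC4C3=O)c3ccccc32)c2cc(Cl)c(Cl)cc21` gives 750 nM

Compound 1 has the higher of the two numbers, making it the weaker inhibitor of the pair, and the gap to compound 2 lies beyond the scatter. Compound 3 `O=C1NC2(C3=C(C(=O)C4C=CC=CC4C3=O)c3cc(Cl)ccc32)c2ccccc21` is not yet measured. It has chloro in place of hydrogen on an aromatic carbon of the core of compound 1 chloro in place of hydrogen on an aromatic carbon and is otherwise unchanged. Among the measured compounds shown here, no single-place step between measured compounds is available, so the only guide is that compound 2, which also carries chlorine, gives 750 nM while compound 1 gives 1900 nM in the same test. In this assay a small move to a lower number is expected, probably not clearly beyond the scatter. The expected step is a 1.7-fold lower number from compound 1 to compound 3 (0.24 log units; within the scatter) on this reading. For compound 3 the estimated value is 1100 nM with a range from 500 nM to 2400 nM expected.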

Compound 3, half-maximal inhibitory concentration: 1390 nM
Compound 3: middle estimate off by 1.3-fold (0.10 log units), on the low side; the measured number falls inside the stated range.
By their numbers in this assay, from the lowest: compounds 2, 3 and 1 (each within the scatter of the next, the first and the last beyond it).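

In this assay, among the compounds shown here, chloro in place of hydrogen on an aromatic carbon of the core gives the first single-place step, a 1.4-fold lower number from compound 1 to compound 3 (0.14 log units; within the scatter) and so the change stays within the scatter. At this carbon, meta to a fused ring and para to a fused ring, a single chloro is therefore tolerated without a clear shift in antiproliferative activity, although one step at one position cannot establish a trend. No measurement available here bears on the reason for the size of this step.

From the compounds shown here alone, it remains open whether an amine, a methoxy group or a carboxylic acid at this same carbon would produce a step beyond the scatter. Going by these compounds, the effect of a single chloro at other aromatic carbons of the core also remains open.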